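A few compounds are considered here, and "the series" means these few. Any claim that something is new, unique, unknown or untested is made for them only; others in the source may bear on it.

In a functional assay on MCF7 cells (Homo sapiens) for inhibition, read by MTT assay, with a stated time of 72 h (on this read-out lower numbers stand for stronger inhibition and higher numbers for weaker inhibition), compound 1 (`C=C(Br)C(=O)Nc1cccc(/C=C/C(=O)Nc2cccc(F)c2)c1`) gives 3300 nM and compound 2 (`C=C(Br)C(=O)Nc1cccc(/C=C/C(=O)Nc2ccc(F)c(F)c2)c1`) gives 2690 nM and the two lie within the scatter of each other, with a 1.2-fold lower number from compound 1 to compound 2 (0.09 log units; within the scatter) as the step. Compound 3 (`C=C(Br)C(=O)Nc1cccc(/C=C/C(=O)Nc2ccc(Cl)cc2)c1`) gives 11000 nM and is the weakest inhibitor of the three. Two modest steps beyond the scatter lead to it, a 3.3-fold higher number from compound 1 to compound 3 (0.52 log units; beyond the scatter) and a 4.1-fold higher number from compound 2 to compound 3 (0.61 log units; beyond the scatter) and both exchange the aryl group on the amide-type nitrogen.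

Compound 4 (`C=C(Br)C(=O)Nc1cccc(/C=C/C(=O)Nc2ccc(C)cc2)c1`) differs from compound 3 in one place, with methyl in place of chloro on an aromatic carbon, para to a large group (methyl in place of chloro on an aromatic carbon). Among the measured compounds shown here, no measured pair makes this exchange, so the two modest steps serve only as a guide to size. For the measured compounds named here, a step of about that size or smaller is therefore expected in this assay, leaning towards lower numbers, since compound 3 holds the highest number so far at 11000 nM and both other compounds stand lower. Most likely it stays within the scatter. The expected step for compound 4 is a 1.6-fold lower number from compound 3 to compound 4 (0.20 log units; within the scatter) as estimated here. For compound 4 the estimated value is 7000 nM (expected range 2800 nM to 17000 nM).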

Compound 4, half-maximal inhibitory concentration: 2500 nM
Beside the measured number, compound 4's estimate is 2.8-fold (0.45 log units) above it; measured number below the stated range.
By their numbers in this assay, from the lowest: compounds 4, 2 and 1 (each within the scatter of the next); then compound 3.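

In this assay, among the compounds shown here, a 4.4-fold lower number from compound 3 to compound 4 (0.64 log units; beyond the scatter), and this is the first step that changes only one group on an aromatic carbon, para to a large group, and still lies beyond the scatter. The exchange of a single heavy atom, chloro for methyl, is thus enough to move the number by a modest step at this position, while the rest of the molecule stays the same. With a 1.1-fold lower number from compound 2 to compound 4 (0.03 log units; within the scatter) and a 1.3-fold lower number from compound 1 to compound 4 (0.12 log units; within the scatter), both within the scatter, the 4-methylphenyl compound cannot be told apart from the 3,4-difluorophenyl and 3-fluorophenyl compounds, so among these four compounds the 4-chlorophenyl group alone stands apart, and no supporting measurement bears on why it does.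

What the compounds shown leave open is whether this position answers as sharply to other groups in the same place, such as a methoxy group, an amine or a carboxylic acid. They also leave open whether a longer chain there would stay within the scatter of compound 4, or whether methyl in place of chloro gives a step of similar size on another aryl pattern.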